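A few compounds are considered here, and "the series" means these few. Any claim that something is new, unique, unknown or untested is made for them only; others in the source may bear on it.

Compound 1 `C/C(=C\COC(=O)Nc1ccccc1)C1=CC(=O)C(C)(C)O1` carries a phenyl group on the amide-type nitrogen of its carbamate. In a functional assay on FM3A cells (Mus musculus) for inhibition (a lower number here means a stronger inhibitor, a higher number a weaker inhibitor), compound 1 gives > 200 ug/mL, which is a limit of the assay and not a number. Compound 2 `C/C(=C\COC(=O)NC(C)(C)C)C1=CC(=O)C(C)(C)O1`, with a tert-butyl group in that place, gives 7.1 ug/mL in this assay. Compound 3 `C/C(=C\COC(=O)NC(C)C)C1=CC(=O)C(C)(C)O1`, with an isopropyl group there, gives 7.2 ug/mL in this assay. The steps of an at least 28-fold lower number from compound 1 to compound 2 (1.44 log units; beyond the scatter) and an at least 27-fold lower number from compound 1 to compound 3 (1.44 log units; beyond the scatter) are both large, while the step of a 1.0-fold higher number from compound 2 to compound 3 (0.01 log units; within the scatter) is small. So compound 3 and compound 2 sit together at one level among the two numbers, and the only other value is a limit.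

Compound 4 `C/C(=C\COC(=O)NC1CCCCC1)C1=CC(=O)C(C)(C)O1` differs from compound 3 by cyclohexyl in place of isopropyl on an amide-type nitrogen. Both earlier exchanges of one saturated alkyl group for another, or of phenyl for such a group, point the same way: a saturated group on that nitrogen goes with a much lower number than phenyl, and the choice among saturated groups, as shown by a 1.0-fold higher number from compound 2 to compound 3 (0.01 log units; within the scatter), hardly matters. Cyclohexyl is another saturated group, so for compound 4 the expected step is a 1.0-fold lower number from compound 3 to compound 4 (0.01 log units; within the scatter), within the scatter. Compound 4 is therefore estimated at 7 ug/mL, with a likely range from 3 ug/mL to 16 ug/mL.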

Compound 4, half-maximal inhibitory concentration: 13 ug/mL
Beside the measured number, compound 4's estimate is 1.9-fold (0.27 log units) below it; the measured number falls inside the stated range.
By their numbers in this assay, from the lowest: compounds 2, 3 and 4 (each within the scatter of the next). At a limit, above all of these: compound 1.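

The position on the amide-type nitrogen accepts a six-membered non-aromatic ring of carbon only as readily as an open branched group: a 1.8-fold higher number from compound 3 to compound 4 (0.26 log units; within the scatter) and a 1.8-fold higher number from compound 2 to compound 4 (0.26 log units; within the scatter) both stay within the scatter, although cyclohexyl has 6 heavy atoms against 3 for isopropyl. Set against phenyl, the same ring gives an at least 15-fold lower number from compound 1 to compound 4 (1.18 log units; beyond the scatter), so among these compounds a ring as such does not go with the high number of compound 1; only the aromatic one does. The value of compound 1 is a limit and not a number, so the size of that step is only a minimum: the limit of > 200 ug/mL in this assay, at which 1 of the 4 values shown sits.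

Still open, as far as these compounds go, is whether a benzyl group or a longer chain such as octyl would stay at this level. So is what an amine or a carboxylic acid on the cyclohexyl ring would do.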